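Methylating a ring nitrogen in a Chk2 kinase series

The source may report more compounds than this note shows. Statements on the series, on what has been measured and on what is new or still open speak of the compounds shown alone.

Of the compounds shown here, three sharing one core have been measured in an assay on isolated protein for inhibition of serine/threonine-protein kinase Chk2 (Homo sapiens), read by mobility shift assay, tested at 30 uM; a lower number here means less inhibition, a higher number more inhibition at the concentration tested (going by the name of the read-out). Compound 1 `COc1cccc(-c2cc3[nH]nc(N)c3c(=O)[nH]2)c1` gives 52% in this assay, the second highest of the three numbers. Compound 2 `COc1ccc(-c2cc3[nH]nc(N)c3c(=O)[nH]2)cc1` gives 43%, which lies within the usual scatter of compound 1, so the two cannot be ordered. Compound 3 `CN1CCN(c2ccc(-c3cc4[nH]nc(N)c4c(=O)[nH]3)cc2)CC1` gives 68%, a number beyond the scatter from compound 1.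

Among the measured compounds shown here, the only single-point step among the measured compounds is a number 25 percentage points higher from compound 2 to compound 3 (beyond the scatter). That step changes a substituent on an aromatic carbon of the outer ring, a different place from the change considered here.

Compound 4 `COc1cccc(-c2cc3c(c(N)nn3C)c(=O)[nH]2)c1` differs from compound 1 in one place: methyl in place of hydrogen on an aromatic nitrogen. For the measured compounds named here, no measured step touches this ring nitrogen, and no other pair in the set differs there either, so the data give no direct guide to the size or direction of the step. The expectation for a number 22 percentage points lower from compound 1 to compound 4 (beyond the scatter) therefore rests only on the fact that the change sits at the core rather than at the outer ring, and is held loosely as a modest decrease with wide uncertainty. Compound 4 is estimated at 30% in this assay, expected to fall between 5% and 55%.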

Compound 4, a percentage reported as inhibition, at one concentration (the size of the read-out at that concentration, not a potency): 31%
The estimate for compound 4 lay 1 percentage points below the measured number; low and high end bracket the measured number.
By their numbers in this assay, from the lowest: compound 4; then compounds 2 and 1 (each within the scatter of the next); then compound 3.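

In this assay, among the compounds shown here, putting a methyl on the aromatic nitrogen of the five-membered ring gives a number 21 percentage points lower from compound 1 to compound 4 (beyond the scatter), which is the first sign in this set that the number responds to a change on the shared core and not only on the outer ring. For the compounds shown here, the change is very small, a single carbon entering where a hydrogen stood, yet the step lies beyond the usual scatter and runs the opposite way to the only earlier step, a number 25 percentage points higher from compound 2 to compound 3 (beyond the scatter), made on an aromatic carbon of the outer ring. Nothing measured here says why the number falls at this nitrogen.

Still open, as far as these compounds go, is whether a larger group on this nitrogen, such as ethyl or a longer chain ending in an amine, would lower the number further or recover some of what the methyl lost. From the compounds shown here alone, it is also open whether the same methyl costs as much when the outer ring carries 4-methylpiperazin-1-yl in place of methoxy, and these single-concentration percentages give no potency for either change.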